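Ethoxy on the anilino ring of compound 2

This account rests on a few compounds, and the source may have more. Where it says the series, first, only, none or still open, it means among the compounds named here.

Measured so far in a functional assay on SAOS-2 cells (Homo sapiens) for antiproliferative activity, read by MTT assay, with a stated time of 72 h; a higher number here means a weaker inhibitor, a lower number a stronger inhibitor:
compound 1 `O=C(C1=C(O)C(=O)N(CCCn2ccnc2)C1c1ccc(Br)cc1)c1ccccc1` gives 31600 nM
compound 2 `O=C(C1=C(Nc2ccccc2)C(=O)N(CCCn2ccnc2)C1c1ccc(Br)cc1)c1ccccc1` gives 24400 nM

Among the measured compounds shown here, compound 2 holds the lowest of the two numbers in this assay, though its only neighbour, compound 1, stands within the scatter of it, so no order between the two can be claimed. The step of a 1.3-fold lower number from compound 1 to compound 2 (0.11 log units; within the scatter) shows this: anilino in place of hydroxy on a double-bonded ring carbon left the number essentially where it was.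

Compound 3 `CCOc1ccc(NC2=C(C(=O)c3ccccc3)C(c3ccc(Br)cc3)N(CCCn3ccnc3)C2=O)cc1` carries one further change: ethoxy in place of hydrogen on an aromatic carbon. This is an ethoxy in place of hydrogen on an aromatic carbon of the anilino ring, para to a large group. For the measured compounds named here, none of the measured steps touches this ring; the one known step, from compound 1 to compound 2, altered the group on the core itself and fell within the scatter. Going by the values given here, there is therefore no measured step that bears on the new change, and no direction beyond the scatter can be read from the data.

Compound 3 is accordingly expected to give about 20000 nM in this assay, within 8000 nM to 50000 nM, an expected step of a 1.2-fold lower number from compound 2 to compound 3 (0.09 log units; within the scatter).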

Compound 3, half-maximal inhibitory concentration: 30900 nM
Estimate against measurement, compound 3: 1.5-fold (0.19 log units) below; the measured number falls inside the stated range.
By their numbers in this assay, from the lowest: compounds 2, 3 and 1 (each within the scatter of the next).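

In this assay, the anilino ring receives its first measured change, and the step of a 1.3-fold higher number from compound 2 to compound 3 (0.10 log units; within the scatter) shows that ethoxy in place of hydrogen on this aromatic carbon, para to a large group, cannot be told apart from hydrogen. Measured against the hydroxy compound, the step of a 1.0-fold lower number from compound 1 to compound 3 (0.01 log units; within the scatter) also stays within the scatter, so (4-ethoxyphenyl)amino on the double-bonded ring carbon reads the same as hydroxy, as anilino did, and the three compounds cannot be put in any firm order. No evidence is available to explain these readings.

The compounds shown leave open whether a different group on this ring, such as an amine, a carboxylic acid or a longer alkoxy chain, would move the number beyond the scatter. They also leave open whether any change to the rest of the molecule, such as a nitrile or a methoxy in place of the bromo group on the other aromatic ring, would separate one compound from another in this assay.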